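The source may hold more compounds than are shown below. What is called first, only, known or untested is meant among the compounds shown, and "the series" means these compounds.

Working notes on the series. Among the measured compounds shown here, in a functional assay on HeLa cells (Homo sapiens) for inhibition, read by MTT assay, with a stated time of 72 h (a lower number here means a stronger inhibitor, a higher number a weaker inhibitor), compound 1 `COc1cc(NC(C)CCCNC(=O)Nc2cccc(Cl)c2)c2ncccc2c1` gives 17000 nM and compound 2 `COc1cc(NC(C)CCCNC(=O)Nc2ccc(Cl)cc2)c2ncccc2c1` gives 18000 nM, so compound 2 stands level with the only other measured compound. Compound 3 `COc1cc(NC(C)CCCNC(=O)NNC(=O)Nc2ccc(O)cc2)c2ncccc2c1` is the next to be read. Its change from compound 2 is ((4-hydroxyphenyl)carbamoyl)amino in place of 4-chlorophenyl on an amide-type nitrogen, with ((4-hydroxyphenyl)carbamoyl)amino in place of 4-chlorophenyl on an amide-type nitrogen. For the measured compounds named here, the single measured step, a 1.1-fold higher number from compound 1 to compound 2 (0.02 log units; within the scatter), exchanges 3-chlorophenyl for 4-chlorophenyl and is the only guide available. Going by the values given here, no measured compound carries the entering group, so that step gives only weak support for any forecast here. In this assay no step beyond the scatter is expected as the central case, with wide room in either direction. The expected change is a 1.1-fold higher number from compound 2 to compound 3 (0.05 log units; within the scatter). The value for compound 3 is estimated at 20000 nM, within an expected range of 6000 nM to 65000 nM.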

Compound 3, half-maximal inhibitory concentration: 85000 nM
Compound 3: middle estimate off by 4.3-fold (0.63 log units), on the low side; measured number above the stated range.
By their numbers in this assay, from the lowest: compounds 1 and 2 (each within the scatter of the next); then compound 3.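

In this assay, ((4-hydroxyphenyl)carbamoyl)amino in place of 4-chlorophenyl on an amide-type nitrogen gives a 4.7-fold higher number from compound 2 to compound 3 (0.67 log units; beyond the scatter), and the same group in place of 3-chlorophenyl gives a 5.0-fold higher number from compound 1 to compound 3 (0.70 log units; beyond the scatter). Among the compounds shown here, the earlier exchange between the two chlorophenyl groups stayed within the scatter, so this is the first change at this position to move the number beyond it, and the move is towards a weaker inhibitor. No evidence at hand accounts for this step.

From the compounds shown here alone, the carbamoylamino link and the hydroxyl enter together, so it remains open which of them goes with the step; 4-hydroxyphenyl directly on the amide-type nitrogen and ((4-chlorophenyl)carbamoyl)amino would part them. Also open, going by these compounds, is how an amine or a carboxylic acid on that phenyl ring would read.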